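The source may report more compounds than this note shows. Statements on the series, on what has been measured and on what is new or still open speak of the compounds shown alone.

Measured in a toxicity assay on THP-1 cells (Homo sapiens) for inhibition; on this read-out higher numbers stand for lower toxicity in this test and lower numbers for higher toxicity in this test:
- compound 1 `COc1ccc(-c2cnc(NC(=O)C3CCNCC3)n2C)cc1`: > 100000 nM
- compound 2 `COc1ccc(-c2cnc(NC(=O)c3ccc(Br)cc3)n2C)cc1`: > 100000 nM
- compound 3 `Cn1c(-c2ccccc2F)cnc1NC(=O)c1ccc(F)cc1`: > 100000 nM

Compound 3 stands at > 100000 nM, which is a limit of the assay and not a number. The entries for compound 1 and compound 2 are limits too.

Compound 4 `Cn1c(-c2ccc(Cl)cc2)cnc1NC(=O)c1ccc(F)cc1` differs from compound 3 in one place: 4-chlorophenyl in place of 2-fluorophenyl on an aromatic carbon. A 4-chlorophenyl takes the place of the 2-fluorophenyl on an aromatic carbon of a five-membered aromatic ring with 2 nitrogen.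

For the measured compounds named here, the only measured step, a step that the two limits leave unreadable from compound 1 to compound 2, lies elsewhere, on a carbonyl carbon, and has no readable size, so it offers no size to carry over. More useful is the shared reading in this assay: the limit of > 100000 nM in this assay, at which 3 of the 3 values shown sit. Going by the values given here, no measured compound goes against this, though three compounds make a small sample.

No step beyond the usual scatter is expected, and so no direction either, which makes the expected change a number no higher from compound 3 to compound 4 (the limit leaves the size open). The assay will quite likely report only a limit again. For compound 4 the estimate is 100000 nM, with an expected range from 40000 nM to 200000 nM.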

Compound 4, half-maximal cytotoxic concentration: 37000 nM
Beside the measured number, compound 4's estimate is 2.7-fold (0.43 log units) above it; the whole stated range lies above it.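

In this assay, the group on this aromatic carbon of the five-membered ring can change the read-out: 4-chlorophenyl in place of 2-fluorophenyl gives an at least 2.7-fold lower number from compound 3 to compound 4 (0.43 log units; beyond the scatter), a move towards higher toxicity in this test. For the compounds shown here, this is the first step in the set that can be read, as the step between compound 1 and compound 2 cannot. It also makes compound 4 the only compound shown with a number rather than a limit: the limit of > 100000 nM in this assay, at which 3 of the 4 values shown sit.

The change swaps both the halogen and its place on the phenyl ring, so the compounds shown cannot separate the chlorine from its position. Going by these compounds, how 2-chlorophenyl, or a phenyl ring carrying an amine or a carboxylic acid, would read at this position also remains open.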